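The source may hold more compounds than are shown below. What is called first, only, known or untested is meant among the compounds shown, and "the series" means these compounds.

The measured compounds:

Compound 1, `COc1cc2cc(Oc3ccc(NC(=O)Nc4cccc(C(F)(F)F)c4)cc3)c(C)nc2cc1OC`. In a functional assay on K562 cells (Homo sapiens) for inhibition, read by sulforhodamine B assay, with a stated time of 48 h (a higher number here means that more compound is tolerated, a lower number that less compound is tolerated), compound 1 gives > 50000 nM, which is a limit of the assay and not a number.

Compound 2, `COc1cc2cc(Oc3ccc(NC(=O)Nc4ccc(Cl)c(C(F)(F)F)c4)cc3)c(C)nc2cc1OC`. In this assay compound 2 gives 23600 nM.

Compound 2 therefore holds the only number shown; the other value sits at the limit of > 50000 nM in this assay, at which 1 of the 2 values shown sits. Going by the values given here, the one measured step, an at least 2.1-fold lower number from compound 1 to compound 2 (0.32 log units; beyond the scatter), was a chloro in place of hydrogen on an aromatic carbon. Compound 3, `COc1cc2cc(Oc3ccc(NC(=O)Nc4ccc(Cl)c(Cl)c4)cc3)c(C)nc2cc1OC`, differs from compound 2 by chloro in place of trifluoromethyl on an aromatic carbon. Among the compounds with values here, no measured step trades a trifluoromethyl for a chloro, so the step from compound 1 to compound 2 bears on it only loosely: it shows that a chloro on this ring is tolerated with a measurable number. The swap is small in size, so a step within the scatter is expected, a 1.1-fold lower number from compound 2 to compound 3 (0.03 log units; within the scatter). Compound 3 is therefore estimated at 22000 nM, in the range 8000 nM to 50000 nM.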

Compound 3, concentration lethal to 50% of the cells: > 100000 nM
Compound 3 was reported as a limit (the forecaster's own chance of this, stated with the estimate: 25%); at least 4.5-fold (0.65 log units) between middle value and limit.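

This position is not indifferent to a swap that changes only a few heavy atoms: chloro in place of trifluoromethyl, ortho to a chloro group, gives an at least 4.2-fold higher number from compound 2 to compound 3 (0.62 log units; beyond the scatter). Compound 2 is thus the only one of the three with a number in this assay, which shows that a chloro on this ring does not by itself give a measurable value, as the earlier step alone might have suggested. Compound 3 is reported as a limit of the assay and not a number, and with limits at both ends the step from compound 1 to compound 3 cannot be read: the limit of > 100000 nM in this assay, at which 1 of the 3 values shown sits.

Whether this position needs trifluoromethyl itself remains open, as no other group is shown there, such as a methyl, a methoxy or a nitrile. From the compounds shown here alone, how an amine or a carboxylic acid at this place would read in this assay also remains open.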